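Methoxy in place of amino on a saturated ring carbon

The source may hold more compounds than are shown below. What is called first, only, known or untested is meant among the compounds shown, and "the series" means these compounds.

In a functional assay for inhibition, with Homo sapiens as the target (a higher number here means a weaker inhibitor, a lower number a stronger inhibitor), two compounds have been measured so far. Compound 1 `COC1(C)CS(=O)(=O)c2cc(C(=O)N=C(N)N)c(C)cc21` gives 321 nM. Compound 2 `Cc1cc2c(cc1C(=O)N=C(N)N)S(=O)(=O)CC2N` gives 692 nM, the higher of the two numbers and therefore the weaker inhibitor, and its gap to compound 1 lies beyond the usual scatter. Compound 3 `COC1CS(=O)(=O)c2cc(C(=O)N=C(N)N)c(C)cc21` has not yet been measured. Its structure departs from that of compound 2 by methoxy in place of amino on a saturated ring carbon, with methoxy in place of amino on a saturated ring carbon. Going by the values given here, no step between measured compounds shows this change on its own, so any forecast is indirect. Among the compounds with values here, the one guide is that compound 1, which also carries a methoxy group, gives 321 nM. In this assay the expected step is a 2.0-fold lower number from compound 2 to compound 3 (0.31 log units; beyond the scatter), a modest move towards a lower number. The estimated value for compound 3 is 340 nM, with an expected range of 130 nM to 900 nM.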

Compound 3, half-maximal inhibitory concentration: 208 nM
Compound 3: the middle estimate sits 1.6-fold (0.21 log units) above what was measured, and the stated range covers the measured number.
By their numbers in this assay, from the lowest: compounds 3 and 1 (each within the scatter of the next); then compound 2.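

In this assay, the change of amino to methoxy on a saturated ring carbon, two ring bonds from the ring sulfur, can now be read on its own as a step beyond the scatter (a 3.3-fold lower number from compound 2 to compound 3 (0.52 log units; beyond the scatter)). Compound 1 had suggested this direction only indirectly, since it also carries a methyl group on that carbon, but hydrogen in place of that methyl gives a step within the scatter (a 1.5-fold lower number from compound 1 to compound 3 (0.19 log units; within the scatter)), so the two methoxy compounds cannot be told apart here. No measurement bears on why the amino and methoxy compounds differ.

Whether this step is particular to methoxy stays open, as the compounds shown do not tell where a hydroxyl, an ethoxy or a dimethylamino group on this carbon would fall. They also leave open how a plain ring methylene at this place would compare.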